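The compounds below may be only part of what the source reports. "The series", "measured", "known", "first", "only" and "open" are said of these compounds alone.

Among the compounds with values here, compound 3 `COc1ccc(-n2nc(C(=O)Nc3ccc(Oc4ccnc5cc(OCCCN6CCN(C)CC6)c(OC)cc45)c(F)c3)c(C)cc2=O)cc1` sits second highest of the three numbers so far in a functional assay on NCI-H460 cells (Homo sapiens) for inhibition, read by MTT assay, with a stated time of 72 h (a lower number here means a stronger inhibitor, a higher number a weaker inhibitor), where compound 3 gives 3660 nM. Its two nearest neighbours are compound 1 `COc1cc2c(Oc3ccc(NC(=O)c4nn(-c5ccccc5C)c(=O)cc4C)cc3F)ccnc2cc1OCCCN1CCN(C)CC1`, which in this assay gives 3420 nM, and compound 2 `COc1ccc(-n2nc(C(=O)Nc3ccc(Oc4ccnc5cc(OCCCN6CCC(C)CC6)c(OC)cc45)c(F)c3)c(C)cc2=O)cc1`, which gives 4650 nM. The two steps that connect them to compound 3 are both small: a 1.1-fold higher number from compound 1 to compound 3 (0.03 log units; within the scatter), and a 1.3-fold lower number from compound 2 to compound 3 (0.10 log units; within the scatter). Compound 4 `COc1cc2c(Oc3ccc(NC(=O)c4nn(-c5ccc(Cl)cc5)c(=O)cc4C)cc3F)ccnc2cc1OCCCN1CCN(C)CC1` differs from compound 3 in one place: chloro in place of methoxy on an aromatic carbon. Within the data shown here, of the measured steps, only the one from compound 1 to compound 3 touches the same ring on the aromatic nitrogen, and that exchange of a 2-methylphenyl for a 4-methoxyphenyl left the number within the scatter. Among the measured compounds shown here, no measured pair speaks to a chloro on that ring, so the expectation for compound 4 rests on that single neighbouring step and on the narrow spread of all three numbers. The step expected from compound 3 to compound 4 in this assay is therefore a 1.0-fold lower number from compound 3 to compound 4 (0.02 log units; within the scatter), that is, none beyond the scatter. Compound 4 is accordingly estimated at 3500 nM in this assay, with a range from 1500 nM to 8000 nM.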

Compound 4, half-maximal inhibitory concentration: 440 nM
The estimate for compound 4 lay 8.0-fold (0.90 log units) above the measured number; the measured number lies below the stated range.
By their numbers in this assay, from the lowest: compound 4; then compounds 1, 3 and 2 (each within the scatter of the next).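

In this assay, the ring on the aromatic nitrogen proves to be a place where the number can move: an 8.3-fold lower number from compound 3 to compound 4 (0.92 log units; beyond the scatter) comes with chloro in place of methoxy on an aromatic carbon, para to a large group, and a 7.8-fold lower number from compound 1 to compound 4 (0.89 log units; beyond the scatter) comes with 4-chlorophenyl in place of 2-methylphenyl. The earlier exchange on this ring, between compound 1 and compound 3, had stayed within the scatter, so among these compounds only the 4-chlorophenyl ring separates itself, and both of its steps are beyond the scatter. Nothing at hand accounts for this lower number.

From the compounds shown here alone, whether the lower number is tied to chloro itself remains open, since fluoro, bromo or trifluoromethyl on the same aromatic carbon, or a chloro elsewhere on that ring, would be needed to tell. Going by these compounds, it also remains open whether the exchange of methoxy for chloro would carry over to compound 2, which has the 4-methylpiperidin-1-yl group in place of the 4-methylpiperazin-1-yl group.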